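Cytotoxicity notes on a substituted amide series

This account rests on a few compounds, and the source may have more. Where it says the series, first, only, none or still open, it means among the compounds named here.

The series is followed in a toxicity assay on THP-1 cells (Homo sapiens) for inhibition; on this read-out higher numbers stand for lower toxicity in this test and lower numbers for higher toxicity in this test. Compound 1 `COc1ccc(C(=O)Nc2ncc(-c3ccc(OC)cc3)n2C)cc1` gives in this assay > 100000 nM, which is a limit of the assay and not a measured number. Compound 2 `COc1ccc(-c2cnc(NC(=O)c3cc(-c4ccccn4)n[nH]3)n2C)cc1` gives in this assay >= 50000 nM, again a limit rather than a number. Going by the values given here, both compounds therefore stand at the low-toxicity end of what this assay reports, as seen in the limit of > 100000 nM in this assay, at which 1 of the 2 values shown sits, and (the limit of >= 50000 nM in this assay, at which 1 of the 2 values shown sits); compound 1 and compound 2 differ in more than one place, and no step between them is computed.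

Compound 3 `COc1ccc(-c2cnc(NC(=O)c3cccc(Cl)c3)n2C)cc1` differs from compound 1 by 3-chlorophenyl in place of 4-methoxyphenyl on a carbonyl carbon. Among the compounds with values here, no measured step between compounds that differ in one place exists, so any expectation rests on the two limits only. Since compound 1 sits at the limit of > 100000 nM in this assay, at which 1 of the 2 values shown sits, compound 3 is expected to stay at low toxicity, with no step beyond the usual scatter. The expected step in this assay is an at least 1.2-fold lower number from compound 1 to compound 3 (0.09 log units; that floor lies within the scatter). For compound 3 the estimated value in this assay is 80000 nM, with a range from 25000 nM to 200000 nM, and a limit rather than a number is the most likely report.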

Compound 3, half-maximal cytotoxic concentration: > 28000 nM
Compound 3: only a limit was reported; the forecaster's own chance of this, stated with the estimate: 70%; the middle value is on the limit's open side.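

In this assay compound 3 gives > 28000 nM, which is a limit and not a number. Compound 1 also stands at a limit, so no step can be read between compound 1 and compound 3. The compounds shown leave open whether 3-chlorophenyl in place of 4-methoxyphenyl on a carbonyl carbon changes the half-maximal cytotoxic concentration at all.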